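Plasma stability of compound 2 and a carboxyphenyl variant

The source may hold more compounds than are shown below. What is called first, only, known or untested is meant among the compounds shown, and "the series" means these compounds.

Among the measured compounds shown here, in an ADME assay on a cell-free system (plasma, Rattus norvegicus) for metabolic stability, read by LC-MS, with a stated time of 60 min, tested at 100 uM (on this read-out higher numbers stand for a more stable compound and lower numbers for a less stable compound), compound 2 `Cc1c(OCCCCOc2ccc(C(=O)O)cc2Cl)ccc(C(=O)CC2CCCC2)c1O` gives 120% and stands highest among the three compounds measured so far. Compound 3 `Cc1c(OCCCCOc2ccccc2C(=O)O)ccc(C(=O)CC(C)C)c1C` gives 99% in this assay, a number that lies beyond the usual scatter below compound 2. Compound 1 `COc1cc(C(=O)O)ccc1OCCCCOc1ccc(C(=O)CC(C)(C)C)c(O)c1C` gives 48%, the furthest from compound 2 and again beyond the scatter.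

Compound 4 `Cc1c(OCCCCOc2cccc(C(=O)O)c2)ccc(C(=O)CC2CCCC2)c1O` has not yet been measured. It differs from compound 2 in one place: 3-carboxyphenyl in place of 4-carboxy-2-chlorophenyl on an oxygen on a saturated carbon. For the measured compounds named here, no step between measured compounds shares this change, so its effect can only be guessed from the spread seen across compound 1, compound 3 and compound 2.

Given that spread, compound 4 is expected to remain in the upper part of the range, and the step of a number 20 percentage points lower from compound 2 to compound 4 (beyond the scatter) is expected to be a modest decrease, close to the edge of the scatter. The estimate for compound 4 in this assay is 100%, with a plausible range from 70% to 125%.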

Compound 4, percent of the compound remaining: 99%
For compound 4 the middle estimate is 1 percentage points above the measured one; measured number inside the range.
By their numbers in this assay, from the lowest: compound 1; then compounds 3 and 4 (each within the scatter of the next); then compound 2.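

This step is the first among the compounds shown to isolate one place: on an oxygen on a saturated carbon, 3-carboxyphenyl in place of 4-carboxy-2-chlorophenyl gives a number 21 percentage points lower from compound 2 to compound 4 (beyond the scatter) in this assay. Among the compounds shown here, it shows that the number in this read-out responds to the aryl group at this place when the rest of the structure stays fixed, which the earlier compounds, differing in several places at once, could not show. No measurement shown accounts for the size of this step.

The change removes the chlorine and alters where the carboxylic acid sits in a single move, leaving open which of the two carries the step. Also open, from the compounds shown here alone, is how a tetrazole or a primary amide in place of the carboxylic acid would read at this place on the core of compound 2.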